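This account rests on a few compounds, and the source may have more. Where it says the series, first, only, none or still open, it means among the compounds named here.

Compounds measured in an assay (Rattus norvegicus) for inhibition of Fatty-acid amide hydrolase 1 (Homo sapiens); a higher number here means a weaker inhibitor, a lower number a stronger inhibitor:

Compound 1, `COC(=O)c1ccccc1-c1cnc(C(=O)CCCCCCc2ccccc2)o1`: 60 nM
Compound 2, `O=C(CCCCCCc1ccccc1)c1ncc(-c2ccccc2C(=O)C(F)(F)F)o1`: 5000 nM
Compound 3, `Nc1ccc(-c2cnc(C(=O)CCCCCCc3ccccc3)o2)cc1`: 90 nM

Compound 3 stands close to compound 1: the number for compound 3 lies within the scatter of that for compound 1, while both lie far below compound 2, whose number is much higher. Going by the values given here, the one measured step, an 83-fold higher number from compound 1 to compound 2 (1.92 log units; beyond the scatter), concerns a change on the aryl ring that hangs from the shared core and does not touch the change now considered.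

Compound 4, `CNC(=O)c1cnc(C(=O)CCCCCCc2ccccc2)o1`, differs from compound 3 at the core itself: methylcarbamoyl in place of 4-aminophenyl on an aromatic carbon. Among the compounds with values here, no measured step bears on this exchange, since every measured compound keeps an aryl ring at this place. What the measured compounds show is that this ring tolerates different groups with numbers from compound 1 to compound 3 within the scatter, but nothing tells how the assay responds to its removal. An upward step is therefore only a guess; compound 4 is expected to show a 3.3-fold higher number from compound 3 to compound 4 (0.52 log units; beyond the scatter), with wide uncertainty. Compound 4 is estimated at 300 nM, between 60 nM and 1500 nM.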

Compound 4, inhibition constant: 7 nM
For compound 4 the middle estimate is 43-fold (1.63 log units) above the measured one, and the stated range ends above it.
By their numbers in this assay, from the lowest: compound 4; then compounds 1 and 3 (each within the scatter of the next); then compound 2.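

In this assay, an aryl ring is not required at this place on the shared core: methylcarbamoyl in place of 4-aminophenyl gives a 13-fold lower number from compound 3 to compound 4 (1.11 log units; beyond the scatter) and so a stronger inhibitor. The earlier compounds shown here all carried an aryl ring here, so they could not show that a smaller group without a ring, with the same counts of hydrogen-bond donors and acceptors as 4-aminophenyl, is not only tolerated but improves the result. No available evidence explains this gain.

The compounds shown do not separate the loss of the ring from the arrival of the amide, which a plain methyl group or a hydrogen at this place would address. They also leave open which parts of the methylcarbamoyl group matter, as a primary carboxamide, a methyl ester, a carboxylic acid or a nitrile could show.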